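An Ester Chain Replaces the Phenylethyl Group

The source may report more compounds than this note shows. Statements on the series, on what has been measured and on what is new or still open speak of the compounds shown alone.

Compound 1 `O=C(Nc1ccc(Cl)c(Cl)c1)c1nc[nH]c1C(=O)NCc1ccc(Cl)cc1` gives 16200 nM in a functional assay on HL-60 cells (Homo sapiens), with a stated time of 2 days; on this read-out lower numbers stand for stronger inhibition and higher numbers for weaker inhibition.
Compound 2 `C[C@@H](NC(=O)c1[nH]cnc1C(=O)Nc1ccc(Cl)c(Cl)c1)c1ccccc1` gives 8800 nM in this assay.
Compound 3 `C[C@H](NC(=O)c1[nH]cnc1C(=O)Nc1ccc(Cl)c(Cl)c1)c1ccccc1` gives 9200 nM in this assay.

Compound 3 holds the second highest of these three numbers. Its nearest neighbour is compound 2, a 1.0-fold higher number from compound 2 to compound 3 (0.02 log units; within the scatter), two structures that share every atom and bond (the fact that compounds 2 and 3 differ only in the configuration as drawn). Its furthest is compound 1, a 1.8-fold lower number from compound 1 to compound 3 (0.25 log units; within the scatter).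

Compound 4 `COC(=O)[C@@H](C)NC(=O)c1[nH]cnc1C(=O)Nc1ccc(Cl)c(Cl)c1` differs from compound 3 by 1-(methoxycarbonyl)ethyl in place of 1-phenylethyl on an amide-type nitrogen. Among the compounds with values here, no measured step removes the aromatic ring in this way; the steps of a 1.8-fold lower number from compound 1 to compound 2 (0.27 log units; within the scatter) and a 1.8-fold lower number from compound 1 to compound 3 (0.25 log units; within the scatter) only reshaped a ring-bearing group and stayed within the scatter. Compound 4 is therefore expected to remain weak in this assay, estimated at 15000 nM, between 5000 nM and 50000 nM. That expectation amounts to a 1.6-fold higher number from compound 3 to compound 4 (0.21 log units; within the scatter), a step not beyond the scatter.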

Compound 4, half-maximal inhibitory concentration: > 62500 nM
Compound 4: only a limit was reported; the forecaster's own chance of this, stated with the estimate: 20%; middle value at least 4.1-fold (0.61 log units) away from the limit.
By their numbers in this assay, from the lowest: compounds 2, 3 and 1 (each within the scatter of the next). At a limit, above all of these: compound 4.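

In this assay the value of compound 4 is a limit (> 62500 nM). Earlier changes on this amide-type nitrogen kept an aromatic ring and stayed within the scatter, whereas 1-(methoxycarbonyl)ethyl, which has no ring, gives steps beyond it (an at least 6.7-fold higher number from compound 3 to compound 4 (0.83 log units; beyond the scatter)) (an at least 7.1-fold higher number from compound 2 to compound 4 (0.85 log units; beyond the scatter)) (an at least 3.8-fold higher number from compound 1 to compound 4 (0.58 log units; beyond the scatter)). This position therefore accepts some reshaping of the ring-bearing group, but not this ring-free ester chain.

From the compounds shown here alone, it remains open whether losing the ring or gaining the ester matters more. A carboxylic acid or a longer chain ending in a phenyl ring at this position could help separate the two.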